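A few compounds are considered here, and "the series" means these few. Any claim that something is new, unique, unknown or untested is made for them only; others in the source may bear on it.

Working notes on a small set of compounds built around the core of compound 1 `C[C@@H](CO)Nc1nc(C(=O)NCc2ccc(F)cc2)c(O)c2ncccc12`. In a toxicity assay on C8166 cells (Homo sapiens) for cytotoxicity, read by MTT assay, with a stated time of 72 h (a higher number here means that more compound is tolerated, a lower number that less compound is tolerated), compound 1 gives 107000 nM, the highest of the three numbers in hand. Compound 2 `CS(=O)(=O)NCCCN(c1nc(C(=O)NCc2ccc(F)cc2)c(O)c2ncccc12)S(C)(=O)=O` gives 64000 nM in this assay, which lies within the scatter of compound 1. Compound 3 `Cc1ccc(S(=O)(=O)Oc2c(C(=O)NCc3ccc(F)cc3)nc(Br)c3cccnc23)cc1` gives 31000 nM in this assay, a lower number beyond the scatter of compound 1. Among the compounds with values here, no two measured compounds differ in a single place, so no measured step is available to guide the next change.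

Compound 4 `O=CNCCCCCCNc1nc(C(=O)NCc2ccc(F)cc2)c(O)c2ncccc12` differs from compound 1 in one place: 6-(formylamino)hexyl in place of 1-(hydroxymethyl)ethyl on a nitrogen on an aromatic ring. Within the data shown here, with no measured step bearing on this change, no shift beyond the scatter is expected, and the estimated step is a 1.3-fold lower number from compound 1 to compound 4 (0.13 log units; within the scatter). Compound 4 is expected to give 80000 nM in this assay, with a range from 35000 nM to 180000 nM.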

Compound 4, half-maximal cytotoxic concentration: 199000 nM
Beside the measured number, compound 4's estimate is 2.5-fold (0.40 log units) below it; the whole stated range lies below it.
By their numbers in this assay, from the lowest: compound 3; then compounds 2, 1 and 4 (each within the scatter of the next, the first and the last beyond it).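

Swapping 1-(hydroxymethyl)ethyl for 6-(formylamino)hexyl on a nitrogen on an aromatic ring gives a 1.9-fold higher number from compound 1 to compound 4 (0.27 log units; within the scatter) in this assay for this first measured step at this position. The position therefore takes a chain of 9 heavy atoms without the defined stereocentre, and the shift stays inside the scatter. No evidence in hand bears on this result. From the compounds shown here alone, whether an amine or a carboxylic acid at the end of a chain here would give a step beyond the scatter remains open, as does the effect of a longer chain.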